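Working notes: hydrogen in place of 4-chlorophenyl on the ring nitrogen

This account rests on a few compounds, and the source may have more. Where it says the series, first, only, none or still open, it means among the compounds named here.

Measured in a functional assay (brain) for inhibition, with Rattus norvegicus as the target; a lower number here means a stronger inhibitor, a higher number a weaker inhibitor:
compound 1, `CCNc1cccnc1N1CCN(CC2(C)CCc3c(C)c(O)c(C)c(C)c3O2)CC1`, 1000 nM
compound 2, `Cc1c(C)c2c(c(C)c1O)CCC(C)(CN1CCN(c3ccccn3)CC1)O2`, 1000 nM
compound 3, `Cc1c(C)c2c(c(C)c1O)CCC(C)(CN1CCN(c3ccc(Cl)cc3)CC1)O2`, 900 nM

Compound 3 sits in one band with the other two: a 1.1-fold lower number from compound 1 to compound 3 (0.05 log units; within the scatter) and a 1.1-fold lower number from compound 2 to compound 3 (0.05 log units; within the scatter) are both within the scatter, so no ranking among the three is supported.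

Compound 4 is `Cc1c(C)c2c(c(C)c1O)CCC(C)(CN1CCNCC1)O2`. Its change from compound 3 is hydrogen in place of 4-chlorophenyl on an amine nitrogen in a ring.

The measured steps that touch the same ring nitrogen are a 1.1-fold lower number from compound 1 to compound 3 (0.05 log units; within the scatter) and a 1.1-fold lower number from compound 2 to compound 3 (0.05 log units; within the scatter); both swap one aromatic group for another and neither moves the number beyond the scatter. The step of no change at the digits printed from compound 1 to compound 2 (within the scatter) removes a substituent from an aromatic carbon and is likewise within the scatter. Within the data shown here, no measured step removes the aromatic group from the ring nitrogen altogether, so there is no direct precedent for the size or direction of this step. For compound 4 the number in this assay is therefore expected with a wide range, and a move toward a higher number is thought somewhat more likely than the reverse; the expected step is a 2.8-fold higher number from compound 3 to compound 4 (0.44 log units; beyond the scatter).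

The estimate for compound 4 is 2500 nM, with a range from 700 nM to 9000 nM.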

Compound 4, half-maximal inhibitory concentration: 1000 nM
For compound 4 the middle estimate is 2.5-fold (0.40 log units) above the measured one; the measured number falls inside the stated range.
By their numbers in this assay, from the lowest: compounds 3, 1, 2 and 4 (each within the scatter of the next).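

In this assay the aromatic group on the ring nitrogen can be removed altogether without leaving the band, with a 1.1-fold higher number from compound 3 to compound 4 (0.05 log units; within the scatter) and no change at the digits printed from compound 2 to compound 4 (within the scatter) and no change at the digits printed from compound 1 to compound 4 (within the scatter) all within the scatter. Among these compounds, the earlier compounds only exchanged one aromatic group for another, so this is the first sign that no aromatic group at all is needed on this amine nitrogen to hold the number: hydrogen, 4-chlorophenyl, pyridin-2-yl and 3-(ethylamino)pyridin-2-yl cannot be told apart here. No supporting data are available to account for this flat result.

On these data alone, all four compounds share one core and stay in one band, so it remains open whether any substituent on this ring nitrogen can move the number at all, for example a benzyl group, an acetyl group, a longer alkyl chain or a chain ending in a carboxylic acid. As far as these compounds go, it is equally open whether the number responds to changes elsewhere, such as replacing the hydroxyl on the shared core with a methoxy group.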